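The compounds below may be only part of what the source reports. "The series", "measured", "known", "first", "only" and "open" are said of these compounds alone.

Within the data shown here, compound 2 `CC(C)c1ccc(-c2nc(SCc3cn(CC(=O)NC(=O)Nc4ccccn4)nn3)nc(Nc3cccc([N+](=O)[O-])c3)c2C#N)cc1` is the only member of the set with a definite number in a functional assay on ECa-109 cells (Homo sapiens) for inhibition, read by MTT assay, with a stated time of 72 h; a lower number here means a stronger inhibitor, a higher number a weaker inhibitor: compound 2 gives 31300 nM. Compound 1 `CC(C)c1ccc(-c2nc(SCc3cn(CC(=O)NC(=O)Nc4ccccn4)nn3)nc(Nc3ccc(F)cc3)c2C#N)cc1` reaches only a limit of the assay (the limit of > 64000 nM in this assay, at which 1 of the 2 values shown sits), and in this assay compound 1 gives > 64000 nM. Among the measured compounds shown here, the single measured step, an at least 2.0-fold lower number from compound 1 to compound 2 (0.31 log units; beyond the scatter), is thus the only guide to how the group on the aromatic nitrogen moves the read-out, and it shows that this position is not inert. Compound 3 `CC(C)c1ccc(-c2nc(SCc3cn(CC(=O)NC(=O)Nc4ccccn4)nn3)nc(Nc3ccccc3O)c2C#N)cc1` differs from compound 2 by 2-hydroxyphenyl in place of 3-nitrophenyl on a nitrogen on an aromatic ring. For the measured compounds named here, no measured step covers this exchange; the 4-fluorophenyl to 3-nitrophenyl step gives a sense of size but nothing on direction for a hydroxyphenyl. The expected step is a 1.4-fold higher number from compound 2 to compound 3 (0.16 log units; within the scatter), likely within the scatter. The estimate for compound 3 in this assay is 45000 nM, with a range from 15000 nM to 140000 nM.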

Compound 3, half-maximal inhibitory concentration: 7380 nM
Compound 3: middle estimate off by 6.1-fold (0.79 log units), on the high side, and the stated range ends above it.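

Exchanging 3-nitrophenyl for 2-hydroxyphenyl on the nitrogen in this assay gives a 4.2-fold lower number from compound 2 to compound 3 (0.63 log units; beyond the scatter) and so shows that this position can move the read-out between two definite values, not only against a limit. Measured against the 4-fluorophenyl group, the exchange gives an at least 8.6-fold lower number from compound 1 to compound 3 (0.93 log units; beyond the scatter) and marks a bound on the gap, not its full size. Compound 1 stands at a limit of the assay: the limit of > 64000 nM in this assay, at which 1 of the 3 values shown sits.

From the compounds shown here alone, whether the lower number of compound 3 belongs to the hydroxyl group itself or to its place on the phenyl ring stays open, and 3-hydroxyphenyl, 2-methoxyphenyl or 2-aminophenyl on the same nitrogen would separate these readings. Also open is whether the order of these compounds holds outside this assay.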